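A few compounds are considered here, and "the series" means these few. Any claim that something is new, unique, unknown or untested is made for them only; others in the source may bear on it.

Measured so far in a functional assay on U-87MG ATCC cells (Homo sapiens) for inhibition, read by MTT assay, with a stated time of 72 h; a higher number here means a weaker inhibitor, a lower number a stronger inhibitor:

compound 1 `COc1cc2c(Oc3ccc(NC(=O)c4nn(-c5ccccc5OC(F)(F)F)c(=O)cc4C)cc3F)ccnc2cc1OCCCN1CCCC1` gives 1280 nM
compound 2 `COc1cc2c(Oc3ccc(NC(=O)c4nn(-c5cccc(F)c5)c(=O)cc4C)cc3F)ccnc2cc1OCCCN1CCCC1` gives 1700 nM
compound 3 `COc1cc2c(Oc3ccc(NC(=O)c4nn(-c5cccc(F)c5)c(=O)cc4C)cc3F)ccnc2cc1OCCCN1CCC(C)CC1` gives 1800 nM

Compound 2 stands second highest of the three numbers. Its nearest neighbour is compound 3, separated by a 1.1-fold higher number from compound 2 to compound 3 (0.02 log units; within the scatter), and its furthest is compound 1, separated by a 1.3-fold higher number from compound 1 to compound 2 (0.12 log units; within the scatter); both gaps lie within the scatter, so the three compounds cannot be ordered on these numbers.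

Compound 4 `COc1cc2c(Oc3ccc(NC(=O)c4nn(-c5ccc(F)c(F)c5)c(=O)cc4C)cc3F)ccnc2cc1OCCCN1CCCC1` is the unmeasured member. It differs from compound 2 by fluoro in place of hydrogen on an aromatic carbon.

Going by the values given here, two measured steps bear on this. The step from compound 1 to compound 2 changes the aryl group on the aromatic nitrogen and reads a 1.3-fold higher number from compound 1 to compound 2 (0.12 log units; within the scatter). The step from compound 2 to compound 3 changes the amine at the end of the chain and reads a 1.1-fold higher number from compound 2 to compound 3 (0.02 log units; within the scatter). Neither change moved this assay beyond its scatter, and the change to compound 4 is smaller than either, a single fluoro added to the same aryl ring. No step beyond the scatter is therefore expected in this assay for compound 4, in either direction.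

The estimate for compound 4 is 1700 nM, with a range of 850 nM to 3400 nM, which means an expected step of no change at the digits printed from compound 2 to compound 4 (within the scatter).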

Compound 4, half-maximal inhibitory concentration: 1400 nM
Estimate against measurement, compound 4: 1.2-fold (0.08 log units) above, and the stated range covers the measured number.
By their numbers in this assay, from the lowest: compounds 1, 4, 2 and 3 (each within the scatter of the next).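

Going by these compounds alone, the added fluoro, ortho to a fluoro group and para to a large group, turns 3-fluorophenyl into 3,4-difluorophenyl and reads (a 1.2-fold lower number from compound 2 to compound 4 (0.08 log units; within the scatter)) in this assay, so this aromatic carbon, not varied among the earlier compounds, takes a second fluoro with no step beyond the scatter. The swap of 3,4-difluorophenyl for 2-(trifluoromethoxy)phenyl on the aromatic nitrogen reads (a 1.1-fold higher number from compound 1 to compound 4 (0.04 log units; within the scatter)), which extends the earlier reading: compounds 1, 2 and 4 carry three different aryl groups there and cannot be ordered on these numbers. No measurement is available that would account for this flat reading.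

Still open, going by these compounds, is whether a group other than fluoro at this same aromatic carbon, such as an amine, a carboxylic acid or a methoxy group, would move the number beyond the scatter. Also open, on these data alone, is whether the 3,4-difluorophenyl group reads the same with 4-methylpiperidin-1-yl at the end of the chain, as in compound 3, in place of pyrrolidin-1-yl.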